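The compounds below may be only part of what the source reports. "The series", "measured", "known", "first", "only" and "open" are said of these compounds alone.

Measured so far in a functional assay on KB cells (Homo sapiens) for antiproliferative activity, read by sulforhodamine B assay, with a stated time of 3 days; on this read-out higher numbers stand for an effect only at larger amounts of compound and lower numbers for an effect already at smaller amounts:
- compound 1 `CCC1=C(O)c2c(oc(-c3ccccc3)cc2=O)C(CC)(CC)C1=O`: > 236 uM, a limit of the assay
- compound 2 `CCC1=C(O)c2c(oc(-c3ccc(C)c(Cl)c3)cc2=O)C(CC)(CC)C1=O`: 39 uM

Going by the values given here, compound 2, at 39 uM, holds the only actual number so far. For compound 1 the result is the limit of > 236 uM in this assay, at which 1 of the 2 values shown sits.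

Compound 3 `CCC1=C(O)c2c(oc(-c3ccc(OC)cc3C)cc2=O)C(CC)(CC)C1=O` comes next: 4-methoxy-2-methylphenyl in place of 3-chloro-4-methylphenyl on an aromatic carbon, with 4-methoxy-2-methylphenyl in place of 3-chloro-4-methylphenyl next to the ring oxygen. Among the compounds with values here, the only measured step on this carbon is an at least 6.0-fold lower number from compound 1 to compound 2 (0.78 log units; beyond the scatter). That step swapped phenyl for 3-chloro-4-methylphenyl, so it suggests that the substituted phenyl matters but gives no direct size for this exchange. A small rise in the number is therefore expected in this assay, with the estimate being a 1.8-fold higher number from compound 2 to compound 3 (0.25 log units; within the scatter). For compound 3 the estimated value is 70 uM, with an expected range of 20 uM to 200 uM.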

Compound 3, concentration for half-maximal effect: 20.9 uM
Compound 3: middle estimate off by 3.3-fold (0.52 log units), on the high side; the measured number falls inside the stated range.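

In this assay, 4-methoxy-2-methylphenyl and 3-chloro-4-methylphenyl next to the ring oxygen cannot be told apart, with a 1.9-fold lower number from compound 2 to compound 3 (0.27 log units; within the scatter). A second substituted phenyl thus also stands clear of phenyl, with an at least 11-fold lower number from compound 1 to compound 3 (1.05 log units; beyond the scatter). Compound 1 stands at a limit, not a number: the limit of > 236 uM in this assay, at which 1 of the 3 values shown sits.

Which single substituent on either ring accounts for the difference from phenyl stays open, since compound 2 and compound 3 each carry two. Also open, as far as these compounds go, is how an amine or a carboxylic acid on this phenyl would read.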